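A few compounds are considered here, and "the series" means these few. Any claim that something is new, unique, unknown or untested is made for them only; others in the source may bear on it.

Measured so far:
Compound 1 `O=C(Oc1ccccc1)N1CCC(CCn2ccc3ncccc32)CC1`: 1700 nM
Compound 2 `O=C(Oc1ccccc1)N1CCC(CCn2ccc3cc(F)ccc32)CC1`: 130 nM
Compound 3 `N#Cc1ccc2c(ccn2CCC2CCN(C(=O)Oc3ccccc3)CC2)c1`: 970 nM

In an assay on microsomes from brain for inhibition of Fatty-acid amide hydrolase 1 (Rattus norvegicus), read by HPLC, with a stated time of 60 min (on this read-out lower numbers stand for stronger inhibition and higher numbers for weaker inhibition), compound 3 sits second highest of the three numbers, close to compound 1 and within the scatter of it, while the gap to compound 2 is beyond it. For the measured compounds named here, the single measured step that touches this ring position is a 7.5-fold higher number from compound 2 to compound 3 (0.87 log units; beyond the scatter). Compound 4 `COc1ccc2c(ccn2CCC2CCN(C(=O)Oc3ccccc3)CC2)c1` differs from compound 3 by methoxy in place of cyano on an aromatic carbon. Going by the values given here, no measured pair shows a methoxy entering or a cyano leaving, so the direction rests on the spread between compound 1, compound 2 and compound 3 alone; a methoxy is expected to land somewhere between them. Compound 4 is therefore expected to give 500 nM in this assay, between 150 nM and 1700 nM, an estimated step of a 1.9-fold lower number from compound 3 to compound 4 (0.29 log units; within the scatter).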

Compound 4, half-maximal inhibitory concentration: 360 nM
Compound 4: middle estimate off by 1.4-fold (0.14 log units), on the high side; measured number inside the range.
By their numbers in this assay, from the lowest: compound 2; then compound 4; then compounds 3 and 1 (each within the scatter of the next).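

In this assay, methoxy in place of cyano on this aromatic carbon gives a 2.7-fold lower number from compound 3 to compound 4 (0.43 log units; beyond the scatter), so exchanging one group for another of equal heavy-atom count here can still move the number beyond the scatter. Methoxy in place of fluoro gives a 2.8-fold higher number from compound 2 to compound 4 (0.44 log units; beyond the scatter), which places methoxy in the middle of the three groups at this position, with fluoro lowest and cyano highest. No data are available here to explain this order. The compounds shown leave open where an amine, a carboxylic acid or a longer alkoxy chain would fall at this carbon.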